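A few compounds are considered here, and "the series" means these few. Any claim that something is new, unique, unknown or untested is made for them only; others in the source may bear on it.

Three compounds share a core, and each has a number in an assay on NIH3T3 cells with Urotensin-2 receptor (Homo sapiens) as the target; on this read-out higher numbers stand for an effect only at larger amounts of compound and lower numbers for an effect already at smaller amounts. Compound 3 `COc1ccc(NC(=O)NC(CCN(C)C)c2ccc(Cl)cc2)cc1` gives 2000 nM, the second highest of the three numbers. Its nearest neighbour is compound 2 `Cc1ccccc1NC(=O)NC(CCN(C)C)c1ccc(Cl)cc1`, which gives 2290 nM; the step of a 1.1-fold lower number from compound 2 to compound 3 (0.06 log units; within the scatter) is within the scatter, so the two cannot be told apart on this read-out. For the measured compounds named here, compound 1 `CN(C)CCC(NC(=O)c1ccc(Oc2ccccc2)cc1)c1ccc(Cl)cc1` gives 66.1 nM, a number far lower than that of compound 3, but it differs from compound 3 in more than one place, so no single step connects the two.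

Compound 4 `CN(C)CCC(NC(=O)Nc1ccc(-c2ccccc2)cc1)c1ccc(Cl)cc1` has not yet been measured. It arises from compound 3 by phenyl in place of methoxy on an aromatic carbon. Going by the values given here, only one measured step exists here, the one from compound 2 to compound 3, and it swaps one small group for another and stays within the scatter; it tells little about a change that puts a whole ring in place of methoxy. Compound 1 shows that a member of this set carrying an extra ring can give a low number, yet its other difference from compound 3 leaves that hint uncertain. The expectation is therefore a step of a 3.3-fold lower number from compound 3 to compound 4 (0.52 log units; beyond the scatter) toward a lower number, with wide uncertainty. Compound 4 is estimated at 600 nM, within a range from 150 nM to 2500 nM.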

Compound 4, half-maximal effective concentration: 145 nM
Compound 4: the middle estimate sits 4.1-fold (0.62 log units) above what was measured; measured number outside the range, below it.
By their numbers in this assay, from the lowest: compound 1; then compound 4; then compounds 3 and 2 (each within the scatter of the next).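

In this assay the step of a 14-fold lower number from compound 3 to compound 4 (1.14 log units; beyond the scatter) is large, which shows that the group on this aromatic carbon, para to a large group, can strongly shift the number. The only other single change shown, the step of a 1.1-fold lower number from compound 2 to compound 3 (0.06 log units; within the scatter) that puts 4-methoxyphenyl in place of 2-methylphenyl on an amide-type nitrogen, gave no difference that can be read on this read-out, so the earlier compounds gave no sign that a single change in this set could matter this much. Nothing at hand bears on why phenyl in this place goes with such a low number.

The compounds shown leave open whether an aromatic ring is needed at this position, or whether a cyclohexyl ring, a pyridine ring or a tert-butyl group in the same place would give a similar number. They also leave open how the number would respond to a further group on the added phenyl ring, such as a carboxylic acid or an amine.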